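The source may hold more compounds than are shown below. What is called first, only, known or untested is meant among the compounds shown, and "the series" means these compounds.

Working notes on the series. Compound 1 (`O=C(CN1CCN(C(=O)c2ccc(Cl)cc2)CC1)N1CCN(CCCc2c[nH]c3ccccc23)CC1`) gives 139000 nM in an ADME assay on SH-SY5Y cells (Homo sapiens) for cytotoxicity, read by MTT assay, with a stated time of 72 h (a higher number here means a weaker inhibitor, a lower number a stronger inhibitor), and serves as the reference here. Compound 3 (`O=C(CN1CCN(C(=O)c2ccc(F)cc2)CC1)N1CCN(CCCc2c[nH]c3ccccc23)CC1`) gives 188000 nM in this assay and the gap reads a 1.4-fold higher number from compound 1 to compound 3 (0.13 log units; within the scatter) so no order can be drawn between the two. Compound 2 (`Cc1ccc(C(=O)N2CCN(CC(=O)N3CCN(CCCc4c[nH]c5ccccc45)CC3)CC2)cc1`) gives > 200000 nM as a limit of the assay and not as a number. Its steps are an at least 1.4-fold higher number from compound 1 to compound 2 (0.15 log units; that floor lies within the scatter) and an at least 1.0-fold lower number from compound 2 to compound 3 (0.02 log units; that floor lies within the scatter) and neither shows a change beyond the scatter. Compound 1 therefore stands with no measured neighbour clearly apart from it.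

Compound 4 (`O=C(CN1CCN(C(=O)c2ccc(Cl)cc2)CC1)N1CCN(CCCc2c[nH]c3ccc(F)cc23)CC1`) differs from compound 1 by one change: fluoro in place of hydrogen on an aromatic carbon that is, fluoro in place of hydrogen on an aromatic carbon, with 1H-indol-3-yl becoming 5-fluoro-1H-indol-3-yl. Within the data shown here, no measured step makes this exchange at this place. All three exchange a group on an aromatic carbon elsewhere in the molecule, so they bear on it only indirectly, and all three stay within the scatter. No step beyond the scatter is expected in this assay and the expected step is a 1.1-fold higher number from compound 1 to compound 4 (0.03 log units; within the scatter) on this estimate. Compound 4 is estimated at 150000 nM with 75000 nM to 250000 nM as the expected range.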

Compound 4, half-maximal inhibitory concentration: 125000 nM
Estimate against measurement, compound 4: 1.2-fold (0.08 log units) above; measured number inside the range.
By their numbers in this assay, from the lowest: compounds 4, 1 and 3 (each within the scatter of the next). At a limit, above all of these: compound 2.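

Among these compounds, the first reading on the 1H-indol-3-yl group comes from the step in this assay (a 1.1-fold lower number from compound 1 to compound 4 (0.05 log units; within the scatter)), whereas the earlier steps all exchanged a group elsewhere in the molecule. Fluoro in place of hydrogen here, on the aromatic carbon para to a fused ring, therefore joins those exchanges in staying within the scatter, and no order can be drawn between 1H-indol-3-yl and 5-fluoro-1H-indol-3-yl on these values. Compound 2 remains a limit of the assay and not a number: the limit of > 200000 nM in this assay, at which 1 of the 4 values shown sits.

On these data alone, whether an amine or a carboxylic acid in place of fluoro at this position would give a step beyond the scatter in this assay stays open, and a single exchange cannot show how other groups would read here. Also open is whether a longer chain in place of the 2-(1H-indol-3-yl)ethyl part of the shared core would move the number, since every step among the compounds shown is either within the scatter or has a floor that lies within it.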